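Swapping Dimethylamino for Hydroxy in an Antiproliferative Series

This account rests on a few compounds, and the source may have more. Where it says the series, first, only, none or still open, it means among the compounds named here.

Three compounds were measured in a functional assay on HCT-8 cells (Homo sapiens) for antiproliferative activity, read by MTT assay, with a stated time of 48 h; a higher number here means a weaker inhibitor, a lower number a stronger inhibitor:
Compound 1, `C=C(c1ccc2c(c1)C=CC(C)(C)O2)c1ccc(OC)cc1NC(=O)CO`: 220 nM
Compound 2, `C=C(c1ccc2c(c1)C=CC(C)(C)O2)c1ccc(OC)cc1NC(=O)CN(C)C`: 690 nM
Compound 3, `C=C(c1cc(OC)c(OC)c(OC)c1)c1ccc(OC)c(O)c1NC(=O)CN(C)C`: 110 nM

Compound 1 and compound 2 share one core and differ only by hydroxy in place of dimethylamino on a saturated chain carbon bound to a carbonyl carbon; that step gave a 3.1-fold lower number from compound 2 to compound 1 (0.50 log units; beyond the scatter). Compound 3 stands on another core, and the difference between the two cores is not broken down here. Compound 4, `C=C(c1cc(OC)c(OC)c(OC)c1)c1ccc(OC)c(O)c1NC(=O)CO`, has not yet been measured; it differs from compound 3 by hydroxy in place of dimethylamino on a saturated chain carbon bound to a carbonyl carbon, the same change at the same place as the one seen before. Because a 3.1-fold lower number from compound 2 to compound 1 (0.50 log units; beyond the scatter) was observed once already, a step of similar size is expected for the second instance, tempered by the change of core. Compound 4 is therefore expected to give about 45 nM, between 15 nM and 130 nM. This estimate corresponds to an expected step of a 2.4-fold lower number from compound 3 to compound 4 (0.39 log units; beyond the scatter).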

Compound 4, half-maximal inhibitory concentration: 40 nM
Compound 4: the middle estimate sits 1.1-fold (0.05 log units) above what was measured; low and high end bracket the measured number.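

In this assay, hydroxy in place of dimethylamino on a saturated chain carbon bound to a carbonyl carbon gave a 2.8-fold lower number from compound 3 to compound 4 (0.44 log units; beyond the scatter) on the second core. The change therefore carried over from one core to the other at much the same size: the same change on two cores in this assay, a 3.1-fold lower number (0.50 log units; beyond the scatter) from compound 2 to compound 1 and a 2.8-fold lower number (0.44 log units; beyond the scatter) from compound 3 to compound 4, 1.1-fold (0.06 log units) apart, within the scatter of two such steps. This rests on a single pair on each of two cores, so it does not show that the step would hold on any further core, and it does not explain why the number falls.

The compounds shown leave open what other groups at this place would do, such as a primary amine, a carboxylic acid or a longer chain ending in hydroxy. They also leave open how the step would look in any other assay.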